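The source may hold more compounds than are shown below. What is called first, only, known or untested is meant among the compounds shown, and "the series" means these compounds.

Compound 1 `O=c1ccoc(/C=C/c2ccccc2)c1` gives 285 uM in a functional assay on U-251 cells (Homo sapiens) for inhibition, read by sulforhodamine B assay, with a stated time of 48 h; a lower number here means a stronger inhibitor of growth, a higher number a weaker inhibitor of growth. Compound 2 `COc1ccc(/C=C/c2cc(=O)cco2)cc1` gives 278 uM in this assay.

Compound 2 holds the lowest of the two numbers, yet the gap to compound 1, a 1.0-fold lower number from compound 1 to compound 2 (0.01 log units; within the scatter), is within the scatter, so the pair cannot be told apart. Compound 3 `COc1ccc(/C=C/c2cc(=O)cco2)cc1OC` differs from compound 2 by methoxy in place of hydrogen on an aromatic carbon. Going by the values given here, the only step that bears on this is a 1.0-fold lower number from compound 1 to compound 2 (0.01 log units; within the scatter), the same kind of change, which stayed within the scatter; no step beyond the scatter is therefore expected in this assay. Compound 3 is estimated to give 270 uM, between 130 uM and 550 uM. The expected step is a 1.0-fold lower number from compound 2 to compound 3 (0.01 log units; within the scatter).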

Compound 3, concentration for growth inhibition (reported as GI): 339 uM
Compound 3: the middle estimate sits 1.3-fold (0.10 log units) below what was measured, within the range that was stated.
By their numbers in this assay, from the lowest: compounds 2, 1 and 3 (each within the scatter of the next).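

Methoxy in place of hydrogen, ortho to a methoxy group and meta to a group of 9 heavy atoms, gives a 1.2-fold higher number from compound 2 to compound 3 (0.09 log units; within the scatter) in this assay and so adds a second position to the earlier result. The same change at two different places on the aromatic ring has now stayed within the scatter, the earlier case being a 1.0-fold lower number from compound 1 to compound 2 (0.01 log units; within the scatter) on the way to this one. No measured evidence bears on this result.

As far as these compounds go, whether an amine or a carboxylic acid at this position would give a step beyond the scatter remains open. The same question stands for a longer chain in place of methoxy.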